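This account rests on a few compounds, and the source may have more. Where it says the series, first, only, none or still open, it means among the compounds named here.

Compound 1 `Cc1ccc(-c2oc3ccc(C(=O)O)cc3c(=O)c2O)cc1` was tested in a functional assay on the whole organism (stomach) for inhibition, with Rattus norvegicus as the target, at a dose of 80 mg/kg (on this read-out lower numbers stand for less inhibition and higher numbers for more inhibition at the one dose given (going by the name of the read-out)), and gave 6%. Going by the values given here, of the three compounds measured so far, compound 1 stands second highest: compound 2 `CC(C)c1ccc(-c2oc3ccc(C(=O)O)cc3c(=O)c2O)cc1` gives 24%, while compound 3 `O=C(O)c1ccc2oc(-c3ccc(Cl)cc3)c(O)c(=O)c2c1` gives -19%. The measured steps all lie in one place, the group on the outer aromatic ring: a number 18 percentage points higher from compound 1 to compound 2 (beyond the scatter), a number 25 percentage points lower from compound 1 to compound 3 (beyond the scatter) and a number 43 percentage points lower from compound 2 to compound 3 (beyond the scatter). Compound 4 `COc1c(-c2ccc(C)cc2)oc2ccc(C(=O)O)cc2c1=O` differs from compound 1 elsewhere, with methyl in place of hydrogen on an oxygen on an aromatic ring. Among the compounds with values here, none of the measured steps touches that oxygen, so no measured step bears directly on this change, and nothing among the three compounds shows how the shared core responds to it. With no guide from the measured steps, the expectation for compound 4 in this assay is a step of no size beyond the scatter, a number 1 percentage points lower from compound 1 to compound 4 (within the scatter). Within the data shown here, compound 4 is therefore estimated to give 5% in this assay, with a range from -20% to 30% that is set wide because the change is untested here and rests on the single value of compound 1, 6%.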

Compound 4, a percentage reported as inhibition, in the whole organism at one dose (the size of the read-out at that dose, not a potency): 4%
Estimate against measurement, compound 4: 1 percentage points above, within the range that was stated.
By their numbers in this assay, from the lowest: compound 3; then compounds 4 and 1 (each within the scatter of the next); then compound 2.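

Swapping hydrogen for methyl on this oxygen, which turns hydroxy into methoxy, gives a number 2 percentage points lower from compound 1 to compound 4 (within the scatter) in this assay, so at this dose the two compounds cannot be told apart. Going by these compounds alone, the earlier compounds showed only that changing the group on the outer aromatic ring can move this number, as in a number 18 percentage points higher from compound 1 to compound 2 (beyond the scatter), while this new step shows that the hydrogen on the oxygen can be capped with methyl without a measurable change from compound 1. No separate measurement is available to explain this result.

This finding rests on a single pair, and compound 1 itself gives only 6%, so it says little about how the change would behave in a compound with a higher number, such as compound 2 with its isopropyl group. It also leaves open whether a longer chain such as ethyl or benzyl, or an acetyl group, on the same oxygen would stay within the scatter as methyl does.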